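The compounds below may be only part of what the source reports. "The series", "measured", "known", "first", "only" and "open" are said of these compounds alone.

Compound 1 `Cc1cc(NC(=O)Cn2nnc(-c3cccc(Cl)c3)n2)n(C2CCCCC2)n1` gives 89% in an assay on HEK293 cells for activation of Kir3.1/Kir3.2 (Homo sapiens), read by thallium flux; a lower number here means a smaller maximal response, a higher number a larger maximal response. Compound 2 `Cc1cc(NC(=O)Cn2nnc(-c3ccccc3F)n2)n(C2CCCCC2)n1` gives 88%. Compound 3 `Cc1cc(NC(=O)Cn2nnc(-c3ccc(F)c(F)c3)n2)n(C2CCCCC2)n1` gives 93%.

Compound 3 carries the largest of the three numbers shown, yet the gap to its nearest neighbour is a number 4 percentage points higher from compound 1 to compound 3 (within the scatter) and to its furthest a number 5 percentage points higher from compound 2 to compound 3 (within the scatter), so all three sit within the scatter of one another and none can be called more active than the rest.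

Compound 4 `COc1ccc(-c2nnn(CC(=O)Nc3cc(C)nn3C3CCCCC3)n2)cc1` differs from compound 3 in one place: 4-methoxyphenyl in place of 3,4-difluorophenyl on an aromatic carbon. The measured steps all exchange one halogen-bearing phenyl for another, and each stayed within the scatter: a number 1 percentage points lower from compound 1 to compound 2 (within the scatter), a number 4 percentage points higher from compound 1 to compound 3 (within the scatter) and a number 5 percentage points higher from compound 2 to compound 3 (within the scatter). Going by the values given here, no measured step exchanges a halogen-bearing phenyl for a methoxy-bearing one, so the change to compound 4 is only loosely covered. With three neighbours so close, the step from compound 3 to compound 4 is expected to be a number 5 percentage points lower from compound 3 to compound 4 (within the scatter), none beyond the scatter, with a wider margin for the untested group. Compound 4 is therefore estimated at 88%, in a range from 65% to 105%.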

Compound 4, largest response reached (Emax), in percent of the reference or control that the assay uses: 90%
The estimate for compound 4 lay 2 percentage points below the measured number; measured number inside the range.
By their numbers in this assay, from the lowest: compounds 2, 1, 4 and 3 (each within the scatter of the next).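

Moving from a halogen-bearing phenyl to one carrying a methoxy group gives a number 3 percentage points lower from compound 3 to compound 4 (within the scatter) and a number 2 percentage points higher from compound 2 to compound 4 (within the scatter) and a number 1 percentage points higher from compound 1 to compound 4 (within the scatter) in this assay, so all three new steps stay small. This position, on the aromatic carbon between two ring nitrogen atoms, therefore accepts 4-methoxyphenyl, which has one hydrogen-bond acceptor where 3,4-difluorophenyl has none, and the maximal response of compound 4 cannot be told apart from those of the halogen-bearing compounds. No supporting data are available to explain this result.

On these data alone, all four compounds carry a substituted phenyl at this position, so it remains open whether an amine or a carboxylic acid on that ring, or a longer chain in its place, would also keep the response within the scatter. As far as these compounds go, the concentration each compound needs to reach its maximal response also remains open.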